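A few compounds are considered here, and "the series" means these few. Any claim that something is new, unique, unknown or untested is made for them only; others in the source may bear on it.

Measured so far in a functional assay on aorta for antagonist activity at Alpha-1D adrenergic receptor (Rattus norvegicus); a lower number here means tighter binding, a higher number weaker binding: compound 1 `COc1ccccc1N1CCN(CCCNc2ncccc2C(=O)N(C)C)CC1` gives 20 nM, compound 2 `CN(C)C(=O)c1cccnc1NCCCN1CCN(c2ccccc2-c2ccccc2)CC1` gives 63.1 nM, and compound 3 `Cc1ccccc1N1CCN(CCCNc2ncccc2C(=O)N(C)C)CC1` gives 10 nM.

Compound 3 sits at the low end of the numbers shown, but it cannot be told apart from compound 1, since the step of a 2.0-fold lower number from compound 1 to compound 3 (0.30 log units; within the scatter) lies within the scatter; only compound 2 stands clearly apart, with a 6.3-fold lower number from compound 2 to compound 3 (0.80 log units; beyond the scatter).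

Compound 4 `CSc1ccccc1N1CCN(CCCNc2ncccc2C(=O)N(C)C)CC1` differs from compound 3 by methylsulfanyl in place of methyl on an aromatic carbon. Among the measured compounds shown here, two measured steps bear on this. Replacing methyl with methoxy, another small group carrying one acceptor, gave a 2.0-fold lower number from compound 1 to compound 3 (0.30 log units; within the scatter), within the scatter, whereas replacing it with the bulky phenyl gave a 6.3-fold lower number from compound 2 to compound 3 (0.80 log units; beyond the scatter). Methylsulfanyl resembles methoxy more than phenyl, so compound 4 is expected to give 16 nM, within 6 nM to 45 nM. The expected step of a 1.6-fold higher number from compound 3 to compound 4 (0.20 log units; within the scatter) is estimated to stay within the scatter.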

Compound 4, dissociation constant: 31.6 nM
Compound 4: the middle estimate sits 2.0-fold (0.30 log units) below what was measured; the measured number falls inside the stated range.
By their numbers in this assay, from the lowest: compounds 3, 1, 4 and 2 (each within the scatter of the next, the first and the last beyond it).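

In this assay, among the compounds shown here, methylsulfanyl in place of methyl gives a 3.2-fold higher number from compound 3 to compound 4 (0.50 log units; beyond the scatter) and so shows that phenyl is not the only group at this position whose step from methyl lies beyond the scatter. Methylsulfanyl cannot be told apart from methoxy, with a 1.6-fold higher number from compound 1 to compound 4 (0.20 log units; within the scatter) for that change, nor from phenyl, with a 2.0-fold lower number from compound 2 to compound 4 (0.30 log units; within the scatter) for that one, although compound 1 and compound 2 stand clear of each other.

On these data alone, whether a chlorine atom, an ethyl group or a hydroxyl group here would read like methyl or like methylsulfanyl remains open. Nothing given here explains these steps.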